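Swapping acetamido for ethyl on a shared core

The source may hold more compounds than are shown below. What is called first, only, known or untested is meant among the compounds shown, and "the series" means these compounds.

Within the data shown here, compound 1, with structure `Cc1ccc2c(c1)N(C1=CCCC1=O)CC(C)(C)S2`, is the only member of this small set for which a result exists: in a functional assay on aorta (Rattus norvegicus, strain Wistar), in the presence of a further agent that is not named here (on this read-out lower numbers stand for smaller maximal responses and higher numbers for larger maximal responses), compound 1 gives 78%. Compound 2, with structure `CC(=O)Nc1ccc2c(c1)N(C1=CCCC1=O)CC(C)(C)S2`, carries an acetamido group on the shared core, and in this assay compound 2 stands as "not determined" (no result reported). Compound 3, with structure `CC1(C)CSc2ccc(C(F)(F)F)cc2N1C1=CCCC1=O`, likewise stands in this assay as "not determined" (no result reported). So compound 2 stands without a number of its own, and nothing in the data fixes where it lies. Compound 4, with structure `CCc1ccc2c(c1)N(C1=CCCC1=O)CC(C)(C)S2`, is separated from compound 2 by the change (ethyl in place of acetamido on an aromatic carbon). Since no number is known for compound 2, no size or direction of step can be read from the data; what can be said is that compound 4 is expected to land near the one measured relative. Compound 4 is estimated to give 75%, within 55% to 95%, because compound 1 gives 78% in this assay.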

Compound 4, largest response reached (Emax), in percent of the reference or control that the assay uses: 69%
Beside the measured number, compound 4's estimate is 6 percentage points above it; the measured number falls inside the stated range.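

In this assay, the shared core shows a number 9 percentage points lower from compound 1 to compound 4 (within the scatter), so at this aromatic carbon a methyl and an ethyl group cannot be told apart, and the longer of the two chains is tolerated in the sense that the response stays within the scatter of the shorter one. Compound 2 and compound 3 have no number, so the steps that involve them cannot be read, and the swap of acetamido for ethyl has no measured size or direction. Nothing available explains the result for compound 4 or gives any property of these groups as measured.

From the compounds shown here alone, it remains open whether a longer chain such as propyl would keep the response in the same range. Going by these compounds, whether an amine or a carboxylic acid on this aromatic carbon would shift it beyond the scatter also remains open.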